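Unsaturation in the acyl chain of tetrahydropyranylmethyl esters

A few compounds are considered here, and "the series" means these few. Any claim that something is new, unique, unknown or untested is made for them only; others in the source may bear on it.

Compound 1 `CCCCCCCC/C=C\CCCCCCCC(=O)OCC1CCCCO1` and compound 2 `O=C(OCC1CCCCO1)c1cccc(-c2ccccc2)c1` share the same ester core and differ only in the acyl part. In an assay on membranes from cerebellum for inhibition of Fatty-acid amide hydrolase 1 (Rattus norvegicus) (on this read-out higher numbers stand for weaker inhibition and lower numbers for stronger inhibition), compound 1 gives 29000 nM, and compound 2 gives 18000 nM. Of the two numbers, that of compound 1 is the highest, yet the gap to compound 2 lies within the scatter, so the two cannot be told apart on these data. Within the data shown here, no step between compounds differing in a single place has been measured.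

Compound 3 `CCCCC/C=C\C/C=C\CCCCCCCC(=O)OCC1CCCCO1` is the unmeasured neighbour of compound 1. The change is hept-1-en-1-yl in place of heptyl on a saturated chain carbon bound to a double-bonded chain carbon. Among the measured compounds shown here, it introduces a double bond into the chain and keeps the ester, the core and the chain length; nothing measured so far speaks to such a change. The step of a 1.2-fold lower number from compound 1 to compound 3 (0.06 log units; within the scatter) is expected to stay within the scatter, with no clear direction. For compound 3 the expected value in this assay is 25000 nM, with a range of 10000 nM to 60000 nM.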

Compound 3, half-maximal inhibitory concentration: 7500 nM
Estimate against measurement, compound 3: 3.3-fold (0.52 log units) above; the whole stated range lies above it.
By their numbers in this assay, from the lowest: compound 3; then compounds 2 and 1 (each within the scatter of the next).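

Among these compounds, on the acyl chain, hept-1-en-1-yl in place of heptyl on a saturated chain carbon bound to a double-bonded chain carbon gives, in this assay, a 3.9-fold lower number from compound 1 to compound 3 (0.59 log units; beyond the scatter), so this position does respond to the change, which the earlier compounds could not show. Ester, core and chain length stay the same in this step, leaving one added double bond as the only structural difference between the two compounds. Nothing available explains why this change lowers the number.

The compounds shown leave open whether a third double bond in the chain or a longer chain would lower the number further. Also open, on these data alone, is whether the same step would hold with an amide in place of the ester.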